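A few compounds are considered here, and "the series" means these few. Any claim that something is new, unique, unknown or untested is made for them only; others in the source may bear on it.

In a functional assay on BCG823 cells (Homo sapiens) for inhibition, read by MTT assay, with a stated time of 72 h (on this read-out higher numbers stand for weaker inhibition and lower numbers for stronger inhibition), compound 1, whose structure is `CNc1nc(C(F)(F)F)c(C(=O)N/N=C/c2cccc(C(F)(F)F)c2)s1`, gives only a limit, namely > 100 ug/mL. Compound 3, with the structure `CN(C(=O)NC(=O)c1cccc(C(F)(F)F)c1)c1nc(C(F)(F)F)c(C(=O)N/N=C/c2cccc(C(F)(F)F)c2)s1`, gives a number in this assay of 4.6 ug/mL. Compound 2, whose structure is `CN(C(=O)NC(=O)c1cccc(C(F)(F)F)c1)c1nc(C(F)(F)F)c(C(=O)N/N=C/c2cc(C(F)(F)F)cc(C(F)(F)F)c2)s1`, gives 5.23 ug/mL in this assay. Compound 3 and compound 2 differ by a single change, (trifluoromethyl in place of hydrogen on an aromatic carbon), and that change produced a step of a 1.1-fold higher number from compound 3 to compound 2 (0.06 log units; within the scatter). The difference between the core of compound 1 and the core of compound 3 is not broken down here; the two differ in more than one place.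

Compound 4, with the structure `CNc1nc(C(F)(F)F)c(C(=O)N/N=C/c2cc(C(F)(F)F)cc(C(F)(F)F)c2)s1`, has not yet been measured in this assay. Within the data shown here, it differs from compound 1 by trifluoromethyl in place of hydrogen on an aromatic carbon, which is the same change, at a place described in the same words, as the one that separates compound 3 from compound 2. Since that change made a step that stayed within the scatter between compound 3 and compound 2, and since compound 1 sits at the limit of > 100 ug/mL in this assay, at which 1 of the 3 values shown sits, compound 4 is expected to give a value at or near the same limit. The step from compound 1 to compound 4 is expected to be a step that the limit leaves unreadable from compound 1 to compound 4. Compound 4 is thus estimated at 120 ug/mL in this assay, with a likely range from 40 ug/mL to 300 ug/mL, and a real chance that only a limit is reported.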

Compound 4, half-maximal inhibitory concentration: > 100 ug/mL
Compound 4: only a limit was reported; the forecaster's own chance of this, stated with the estimate: 75%; the middle value does not contradict the limit.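

In this assay compound 4 gives only a limit, > 100 ug/mL. Compound 1 also gives only a limit, > 100 ug/mL, so the step between these two compounds cannot be read: the limit of > 100 ug/mL in this assay, at which 2 of the 4 values shown sit. The compounds shown leave open where compound 1 and compound 4 actually lie beyond the limit, and so whether trifluoromethyl in place of hydrogen acts on them as it does between compound 3 and compound 2.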